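A few compounds are considered here, and "the series" means these few. Any claim that something is new, unique, unknown or untested is made for them only; others in the source may bear on it.

Compound 2 `COC(=O)c1ccc(NCc2cncn2Cc2cccc(C)c2)cc1-c1ccccc1` is one of two compounds tested in a toxicity assay on NIH3T3 cells (Mus musculus) for cytotoxicity, read by resazurin assay; on this read-out higher numbers stand for an effect only at larger amounts of compound and lower numbers for an effect already at smaller amounts. In this assay compound 2 reaches only the limit of > 10000 nM, so no number is known for it, only that the effect did not appear within the tested range. The other measured compound, compound 1 `O=C(c1ccc(NCc2cncn2Cc2ccc(-c3ccccc3)cc2)cc1-c1ccccc1)N1CCCCC1`, also stops at a limit: in this assay compound 1 gives > 1000 nM. Both values are thus limits, one sitting at the limit of > 10000 nM in this assay, at which 1 of the 2 values shown sits, and the other at the limit of > 1000 nM in this assay, at which 1 of the 2 values shown sits, and neither can be set against the other as a number.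

Compound 3 `COC(=O)c1ccc(NCc2cncn2Cc2ccc(C)cc2)cc1-c1ccccc1` differs from compound 2 by one change, (4-methylphenyl in place of 3-methylphenyl on a saturated chain carbon bound to an aromatic nitrogen). For the measured compounds named here, no measured step of this kind is available among the compounds here. Compound 3 is expected to behave much like compound 2, with a step from it of a step that the limit leaves unreadable from compound 2 to compound 3, none beyond the scatter. The estimate for compound 3 is 20000 nM, within 8000 nM to 60000 nM.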

Compound 3, half-maximal effective concentration: 50000 nM
The estimate for compound 3 lay 2.5-fold (0.40 log units) below the measured number, and the stated range covers the measured number.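

For the compounds shown here, compound 2 stands only at a limit in this assay, and no step from it to compound 3 can be read. The compounds shown leave open whether 4-methylphenyl in place of 3-methylphenyl changes the result in this assay at all, and by how much.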